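Swapping the aryl ketone of compound 1 for a dimethoxyphenyl

This account rests on a few compounds, and the source may have more. Where it says the series, first, only, none or still open, it means among the compounds named here.

The measured compounds and their values in a functional assay on MDA-MB-468 cells (Homo sapiens) for cytotoxicity, read by sulforhodamine B assay, with a stated time of 48 h, tested at 0.01 uM; a higher number here means a weaker effect of the compound at the concentration tested, a lower number a stronger effect:
Compound 1 `COc1cc(-c2cc(/C=C/C(=O)c3ccc(Cl)c(Cl)c3)[nH]n2)cc(OC)c1OC` — compound 1 gives 94%.
Compound 2 `COc1ccc(-c2cc(/C=C/C(=O)c3ccc(N)cc3)[nH]n2)cc1OC` — compound 2 gives 94%.
Compound 3 `COc1ccc(-c2cc(/C=C/C(=O)c3cc(OC)c(OC)c(OC)c3)[nH]n2)cc1OC` — compound 3 gives 98%.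

On these numbers compound 1 sits level with compound 2 at the digits shown, the two together being the lowest of the three; its nearest neighbour is compound 2, with no change at the digits shown, and its furthest is compound 3, whose number is higher by an amount that stays within the scatter. All three compounds therefore show about the same small effect at this concentration.

Compound 4 `COc1ccc(C(=O)/C=C/c2cc(-c3cc(OC)c(OC)c(OC)c3)n[nH]2)cc1OC` is not yet measured. It differs from compound 1 in one place: 3,4-dimethoxyphenyl in place of 3,4-dichlorophenyl on a carbonyl carbon. For the measured compounds named here, no step between measured compounds isolates this change. Since compound 3, which also carries a methoxylated aryl group on the carbonyl carbon, gives 98%, compound 4 is expected to remain in the same region, with a step of a number 1 percentage points higher from compound 1 to compound 4 (within the scatter) that is not expected to exceed the scatter. For compound 4 the estimate in this assay is 95%, with a range from 85% to 102%.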

Compound 4, a percentage reported as activity, at one concentration (the size of the read-out at that concentration, not a potency): 89%
Estimate against measurement, compound 4: 6 percentage points above; measured number inside the range.
By their numbers in this assay, from the lowest: compounds 4, 1, 2 and 3 (each within the scatter of the next).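

In this assay, for the compounds shown here, the swap gives a number 5 percentage points lower from compound 1 to compound 4 (within the scatter) on replacing 3,4-dichlorophenyl with 3,4-dimethoxyphenyl on a carbonyl carbon, the first change at this position that can be read in isolation. The two compounds cannot be told apart at this concentration, even though the entering group counts hydrogen-bond acceptors where the leaving group counts none and its oxygen atoms replace chlorine. Nothing available bears on why the read-out holds here.

On these data alone, whether a nitrile, a trifluoromethyl group or a carboxylic acid on this aryl ring would carry the read-out beyond the scatter remains open. As far as these compounds go, it also remains open whether compound 1 and compound 4 would separate at a higher concentration, since a single low dose shows only a small effect for both.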